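Methoxybenzyl amides: from compound 1 to compound 4

This account rests on a few compounds, and the source may have more. Where it says the series, first, only, none or still open, it means among the compounds named here.

Compound 1 `COc1cccc(CNC(=O)c2nc(Br)c3cccnc3c2N[C@H]2CC[C@H](N)CC2)c1`: in a functional assay on HCT-116 cells (Homo sapiens) for cytotoxicity, read by MTT assay, with a stated time of 72 h (on this read-out lower numbers stand for stronger inhibition and higher numbers for weaker inhibition), compound 1 gives 6000 nM.
Compound 2 `O=C(NCc1ccc(F)cc1)c1nc(Br)c2cccnc2c1NCc1ccccc1`: in this assay compound 2 gives > 20000 nM, which is a limit of the assay and not a number.
Compound 3 `O=C(NCc1ccc(F)cc1)c1nc(NCCO)c2cccnc2c1O`: in this assay compound 3 is recorded as "not determined" (no result reported).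

Compound 1 therefore carries the only numerical result in this small set. Compound 2 sits at the limit of > 20000 nM in this assay, at which 1 of the 3 values shown sits, and compound 3 has no result at all. Within the data shown here, no two measured compounds differ in a single place, so no measured step is available to calibrate the size of a change.

Compound 4 `COc1ccc(CNC(=O)c2nc(Br)c3cccnc3c2N[C@H]2CC[C@H](N)CC2)cc1` is the next compound to be measured. It differs from compound 1 in one place only: 4-methoxyphenyl in place of 3-methoxyphenyl on a saturated chain carbon bound to an amide-type nitrogen. The shared core and every other substituent are the same in both compounds.

Without a measured step to set a scale, the expectation for this change is conservative. The step of no change at the digits printed from compound 1 to compound 4 (within the scatter) is expected to stay within the usual scatter of repeated measurements, with no clear direction either way. Compound 4 is accordingly expected to give about 6000 nM in this assay, with a plausible range from 2500 nM to 15000 nM.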

Compound 4, half-maximal inhibitory concentration: 3000 nM
Compound 4: the middle estimate sits 2.0-fold (0.30 log units) above what was measured; measured number inside the range.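

In this assay, among these compounds, 4-methoxyphenyl in place of 3-methoxyphenyl on a saturated chain carbon bound to an amide-type nitrogen gives the first measured step: a 2.0-fold lower number from compound 1 to compound 4 (0.30 log units; within the scatter). The two compounds therefore cannot be told apart on this read-out, and at this place the methoxy group can sit as in either 3-methoxyphenyl or 4-methoxyphenyl without a step beyond the scatter, which also gives the series its first, small reference point for the size of a change. Nothing measured here bears on why the two compounds read alike.

This single step covers one exchange of two groups with the same atoms, so it does not show whether the same place would respond to a different group, such as 2-methoxyphenyl, unsubstituted phenyl or a phenyl ring carrying a carboxylic acid. Among the compounds shown here, also open is how much of the cytotoxicity of compound 1 and compound 4 depends on the rest of the shared core, including the amine-bearing ring, since no single-place step at any other part of the structure is available.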